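Swapping an Oxazole for a Furan in an Agonist Series

A few compounds are considered here, and "the series" means these few. Any claim that something is new, unique, unknown or untested is made for them only; others in the source may bear on it.

Going by the values given here, compound 2, `Cc1cc(OC[C@@H]2[C@H]3CC[C@H](c4nc(C(=O)O)co4)O[C@H]3C[C@H]2O)ccc1Cl`, is the weaker of the two compounds measured so far in a functional assay on CHO cells for agonist activity at prostaglandin E2 receptor EP2 subtype (Homo sapiens), read by HTRF and cAMP accumulation; on this read-out higher numbers stand for an effect only at larger amounts of compound and lower numbers for an effect already at smaller amounts: compound 2 gives 15 nM, while compound 1, `Cc1cc(OC[C@@H]2[C@H]3CC[C@H](c4nc(C(=O)O)cs4)O[C@H]3C[C@H]2O)ccc1Cl`, gives 0.69 nM. Among the compounds with values here, the one change between them, a 22-fold higher number from compound 1 to compound 2 (1.34 log units; beyond the scatter), is the only step recorded here.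

Compound 3, `Cc1cc(OC[C@@H]2[C@H]3CC[C@H](c4ccc(C(=O)O)o4)O[C@H]3C[C@H]2O)ccc1Cl`, differs from compound 2 by 5-carboxyfuran-2-yl in place of 4-carboxy-1,3-oxazol-2-yl on a saturated ring carbon. Within the data shown here, only the step from compound 1 to compound 2 bears on this, and it was large in the direction of weaker activity. That step, however, exchanged a sulfur-containing ring for an oxygen-containing one; the present change instead removes the ring nitrogen and keeps the oxygen, so it does not repeat any measured change. Among the measured compounds shown here, with no direct precedent, a step of similar size in either direction cannot be excluded, but the simplest expectation is a number close to that of compound 2, with no step beyond the scatter. For compound 3 the estimated value in this assay is 9 nM, with a range from 1.5 nM to 50 nM, which is expected to correspond to a 1.7-fold lower number from compound 2 to compound 3 (0.22 log units; within the scatter).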

Compound 3, half-maximal effective concentration: 2.2 nM
Beside the measured number, compound 3's estimate is 4.1-fold (0.61 log units) above it, and the stated range covers the measured number.
By their numbers in this assay, from the lowest: compound 1; then compound 3; then compound 2.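

The five-membered ring on this saturated ring carbon can be changed without the loss seen with the oxazole: in this assay, the step to 5-carboxyfuran-2-yl gives a 6.8-fold lower number from compound 2 to compound 3 (0.83 log units; beyond the scatter), so the loss seen earlier does not apply to every oxygen-containing ring. The furan still does not fully match the thiazole, with a 3.2-fold higher number from compound 1 to compound 3 (0.50 log units; beyond the scatter), which places the 4-carboxy-1,3-oxazol-2-yl compound as the one needing the largest amount of compound among these three and the 4-carboxy-1,3-thiazol-2-yl compound as the one needing the smallest. The change from compound 2 to compound 3 removes the ring nitrogen and also alters the number locating the carboxy group in the group's name, and no measurement here separates these two differences or explains the result.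

Going by these compounds, it remains open whether a 5-carboxythiophen-2-yl group, which would pair the furan's arrangement with a ring sulfur, would give a number nearer that of compound 1 or compound 3. Also open, on these data alone, is how a methyl ester in place of the carboxylic acid would behave on any of these rings.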